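The compounds below may be only part of what the source reports. "The series", "measured", "known", "first", "only" and "open" are said of these compounds alone.

Compound 1 `CCCCOc1ccc2nncn2n1`: > 100 mg/kg in a functional assay on the whole organism with Mus musculus as the target (on this read-out higher numbers stand for an effect only at larger amounts of compound and lower numbers for an effect already at smaller amounts), a limit of the assay.
Compound 2 `CCCCCCCOc1ccc2nncn2n1`: 42.4 mg/kg in this assay.
Compound 3 `CCCCCCCCOc1ccc2nncn2n1`: > 100 mg/kg in this assay, a limit of the assay.

Compound 3 thus stands at the upper limit of this assay, where two of the three values shown sit (the limit of > 100 mg/kg in this assay, at which 2 of the 3 values shown sit). Compound 4 `CCCCCCCCCOc1ccc2nncn2n1` differs from compound 3 by methyl in place of hydrogen on a saturated chain carbon, eight bonds along the chain from an oxygen on an aromatic ring. Among the measured compounds shown here, two measured steps bear on this change: the lengthening by one carbon in an at least 2.3-fold higher number from compound 2 to compound 3 (0.37 log units; beyond the scatter), and the larger extension in an at least 2.3-fold lower number from compound 1 to compound 2 (0.37 log units; beyond the scatter). The nearest step, one carbon added to compound 2, moved the value to the limit. The step from compound 3 to compound 4 is expected to be a step that the limit leaves unreadable from compound 3 to compound 4. Compound 4 is therefore expected to give 150 mg/kg, between 60 mg/kg and 400 mg/kg, most likely again only as a limit.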

Compound 4, dose for half-maximal effect: > 100 mg/kg
Compound 4: no number, only a limit; the forecaster's own chance of this, stated with the estimate: 75%; the middle value is on the limit's open side.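

Lengthening the chain past compound 2 by one more carbon does not bring back a readable effect, with an at least 2.3-fold higher number from compound 2 to compound 4 (0.37 log units; beyond the scatter). The steps from compound 3 to compound 4 and from compound 1 to compound 4 cannot be read, as both ends of each are limits. Two successive chain lengths beyond compound 2 now sit at the limit, and among these four compounds only compound 2 gives a number: the limit of > 100 mg/kg in this assay, at which 3 of the 4 values shown sit.

On these data alone, how far beyond the limit compound 1, compound 3 and compound 4 lie stays open, so no order among them can be given. Also open, as far as these compounds go, is what a chain ending in an amine or a carboxylic acid would give in this assay.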